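Adding a nitrile to the fused ring of compound 1

This account rests on a few compounds, and the source may have more. Where it says the series, first, only, none or still open, it means among the compounds named here.

Measured in a functional assay on HCT-116 cells (Homo sapiens) for antiproliferative activity, read by MTT assay, with a stated time of 72 h; a higher number here means a weaker inhibitor, a lower number a stronger inhibitor:
compound 1, `CN(C(=O)c1ccccc1)c1ccc2[nH]c(-c3n[nH]c4ccccc34)cc2n1`, gives 10600 nM
compound 2, `CN(C(=O)c1ccc(F)cc1)c1ccc2[nH]c(-c3n[nH]c4ccccc34)cc2n1`, gives 9270 nM

Compound 1 holds the highest of the two numbers in this assay, and compound 2 sits nearest to it, the two within the scatter of each other. Among the compounds with values here, the only measured step, a 1.1-fold lower number from compound 1 to compound 2 (0.06 log units; within the scatter), changes the benzoyl part of the molecule and so does not test the position altered here.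

Compound 3, `CN(C(=O)c1ccccc1)c1ccc2[nH]c(-c3n[nH]c4cc(C#N)ccc34)cc2n1`, differs from compound 1 by cyano in place of hydrogen on an aromatic carbon. Within the data shown here, no measured pair touches this fused ring, so nothing in the data points to a step in either direction beyond the scatter. The number expected for compound 3 is therefore close to that of compound 1, with a step of a 1.1-fold lower number from compound 1 to compound 3 (0.03 log units; within the scatter). For compound 3 the estimate in this assay is 10000 nM, expected to fall between 4000 nM and 25000 nM.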

Compound 3, half-maximal inhibitory concentration: 24000 nM
For compound 3 the middle estimate is 2.4-fold (0.38 log units) below the measured one; measured number inside the range.
By their numbers in this assay, from the lowest: compounds 2 and 1 (each within the scatter of the next); then compound 3.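

Within the data shown here, until now the only measured step lay in the benzoyl part, so this is the first reading of a change on the fused ring. In this assay the nitrile gives a 2.3-fold higher number from compound 1 to compound 3 (0.35 log units; beyond the scatter) and so moves the compound towards weaker inhibition, which shows that this aromatic carbon is not indifferent to substitution, even though the step is modest. Nothing at hand accounts for the step.

The compounds shown leave open whether the rise belongs to the nitrile itself or would follow any group on this carbon, and a methoxy group or an amine there would help to separate the two readings. They also leave open whether the nitrile would have a step of similar size when combined with the fluoro group of compound 2.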